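Swapping the Aryl on the Hydrazone Carbon

The compounds below may be only part of what the source reports. "The series", "measured", "known", "first", "only" and "open" are said of these compounds alone.

Measured compounds in a functional assay on BCG823 cells (Homo sapiens) for inhibition, read by MTT assay, with a stated time of 72 h; on this read-out higher numbers stand for weaker inhibition and lower numbers for stronger inhibition:
compound 1 `CN(C(=O)NC(=O)c1ccc([N+](=O)[O-])cc1)c1nc(C(F)(F)F)c(C(=O)N/N=C/c2ccc([N+](=O)[O-])cc2)s1`, 7.45 ug/mL
compound 2 `CN(C(=O)NC(=O)c1ccc(Cl)c(Cl)c1)c1nc(C(F)(F)F)c(C(=O)N/N=C/c2ccc([N+](=O)[O-])cc2)s1`, 2.13 ug/mL
compound 3 `CN(C(=O)NC(=O)c1ccc(F)c(F)c1)c1nc(C(F)(F)F)c(C(=O)N/N=C/c2ccc([N+](=O)[O-])cc2)s1`, 2.99 ug/mL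

Compound 1 gives the highest of the three numbers in this assay; its nearest neighbour is compound 3, and compound 2 lies furthest from it. The two measured steps away from compound 1, a 3.5-fold lower number from compound 1 to compound 2 (0.54 log units; beyond the scatter) and a 2.5-fold lower number from compound 1 to compound 3 (0.40 log units; beyond the scatter), both alter the group on a carbonyl carbon and both lead to lower numbers, while a 1.4-fold higher number from compound 2 to compound 3 (0.15 log units; within the scatter) stays within the scatter.

Compound 4 `CN(C(=O)NC(=O)c1ccc([N+](=O)[O-])cc1)c1nc(C(F)(F)F)c(C(=O)N/N=C/c2cccc(C(F)(F)F)c2)s1` changes compound 1 elsewhere: 3-(trifluoromethyl)phenyl in place of 4-nitrophenyl on a carbon with a double bond to nitrogen. No measured step touches this position, so the direction of the change cannot be read from the data shown. Within the data shown here, the only guidance is that every modification of compound 1 measured so far gave a lower number, which supports expecting, at most, a modest shift in that direction, with wide uncertainty; the expected step is a 1.5-fold lower number from compound 1 to compound 4 (0.17 log units; within the scatter). Compound 4 is therefore estimated at 5 ug/mL, within a range of 1.8 ug/mL to 14 ug/mL.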

Compound 4, half-maximal inhibitory concentration: 1.67 ug/mL
Compound 4: the middle estimate sits 3.0-fold (0.48 log units) above what was measured; the whole stated range lies above it.
By their numbers in this assay, from the lowest: compounds 4, 2 and 3 (each within the scatter of the next); then compound 1.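

At the carbon with a double bond to nitrogen, the aryl group also moves the number: in this assay, 3-(trifluoromethyl)phenyl in place of 4-nitrophenyl gives a 4.5-fold lower number from compound 1 to compound 4 (0.65 log units; beyond the scatter). Among these compounds, the earlier steps changed only the group on a carbonyl carbon, so this is the first sign that the core of compound 1 responds to a change at a second place. Nothing measured here accounts for this step, and it cannot be assigned to a single feature of either group.

From the compounds shown here alone, whether the step depends on the incoming 3-(trifluoromethyl)phenyl or on the loss of 4-nitrophenyl remains open, and a plain phenyl or an aminophenyl at this carbon would help separate the two. Also unresolved is whether 3-(trifluoromethyl)phenyl here would combine with 3,4-dichlorophenyl on the carbonyl carbon to give a still lower number.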